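The source may hold more compounds than are shown below. What is called first, only, known or untested is meant among the compounds shown, and "the series" means these compounds.

Of the compounds shown here, three built on one shared core have been tested in a functional assay on PC-3 cells (Homo sapiens) for cytotoxicity, read by MTT assay, with a stated time of 48 h; on this read-out lower numbers stand for stronger inhibition and higher numbers for weaker inhibition. Compound 1 `COc1cc(-c2nnc3n2NC(c2ccco2)C(C(=O)c2ccc(Br)cc2)S3)cc(OC)c1OC` gives 36400 nM. Compound 2 `COc1cc(-c2nnc3n2NC(c2ccco2)C(C(=O)c2cccs2)S3)cc(OC)c1OC` gives 46200 nM, and compound 3 `COc1cc(-c2nnc3n2NC(c2ccco2)C(C(=O)c2ccc(O)cc2)S3)cc(OC)c1OC` gives 38300 nM. Compound 1 shows the lowest of these three numbers, but the gap to compound 3 is a 1.1-fold higher number from compound 1 to compound 3 (0.02 log units; within the scatter) and the gap to compound 2 is a 1.3-fold higher number from compound 1 to compound 2 (0.10 log units; within the scatter), so the three cannot be told apart on this read-out.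

Compound 4 `COc1cc(-c2nnc3n2NC(c2ccco2)C(C(=O)c2ccc([N+](=O)[O-])cc2)S3)cc(OC)c1OC` has not yet been measured. It differs from compound 1 by nitro in place of bromo on an aromatic carbon. The nearest guide is the change from compound 1 to compound 3, where hydroxy replaced bromo on an aromatic carbon and the number moved a 1.1-fold higher number from compound 1 to compound 3 (0.02 log units; within the scatter). Exchanging the whole aryl group on the carbonyl carbon, a 1.3-fold higher number from compound 1 to compound 2 (0.10 log units; within the scatter) and a 1.2-fold lower number from compound 2 to compound 3 (0.08 log units; within the scatter), also stayed within the scatter. Every change tried on this part of the molecule has left the read-out essentially unchanged, and nothing in these data points to a different outcome for nitro. Compound 4 is therefore expected to show a step of a 1.0-fold higher number from compound 1 to compound 4 (0.01 log units; within the scatter). The estimate for compound 4 is 37000 nM, with a range from 17000 nM to 80000 nM.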

Compound 4, half-maximal inhibitory concentration: 27900 nM
The estimate for compound 4 lay 1.3-fold (0.12 log units) above the measured number, and the stated range covers the measured number.
By their numbers in this assay, from the lowest: compounds 4, 1, 3 and 2 (each within the scatter of the next).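

In this assay, nitro brings three heavy atoms and two hydrogen-bond acceptors to the aromatic carbon where a single bromine stood, and this larger change gives a 1.3-fold lower number from compound 1 to compound 4 (0.12 log units; within the scatter) as its step. Going by these compounds alone, the comparison with the hydroxy group gives a 1.4-fold lower number from compound 3 to compound 4 (0.14 log units; within the scatter) as its step, and exchanging the thiophen-2-yl group for 4-nitrophenyl gives a 1.7-fold lower number from compound 2 to compound 4 (0.22 log units; within the scatter) as the widest step so far, so even this group does not separate the four compounds. No accompanying measurement bears on this result and no explanation can be offered for these small differences.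

An amine, a carboxylic acid or a longer chain on this aromatic carbon remains untested among the compounds shown. These compounds also leave open whether changes elsewhere on the shared core would move the read-out beyond the scatter.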